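Swapping the hydroxy of compound 3 for methylsulfanyl

The source may report more compounds than this note shows. Statements on the series, on what has been measured and on what is new or still open speak of the compounds shown alone.

Compound 3 (`CSc1ccc(C2=C(c3ccc(O)cc3)C(=O)N3CCCC3C2)cc1`) gives > 100000 nM in a functional assay on SW-620 cells (Homo sapiens) for cytotoxicity (a lower number here means a stronger inhibitor of growth, a higher number a weaker inhibitor of growth), as its reading, which is a limit and not a number. Compound 4 (`CSc1ccc(C2=C(c3ccc(SC)cc3)C(=O)N3CCCC3C2)cc1`) has methylsulfanyl in place of hydroxy on an aromatic carbon. In this assay compound 1 (`COc1ccc(C2=C(c3ccc(SC)cc3)CC3CCCN3C2=O)cc1Br`) gives 5000 nM and compound 2 (`CSc1ccc(C2=C(c3ccc(O)c(O)c3)C(=O)N3CCCC3C2)cc1`) gives 50000 nM as measured numbers. Among the compounds with values here, the one member without any hydroxy has the lowest number: steps of a 10-fold higher number from compound 1 to compound 2 (1.00 log units; beyond the scatter) and an at least 20-fold higher number from compound 1 to compound 3 (1.30 log units; beyond the scatter) lead away from it, one modest and one large. Going by compound 1 at 5000 nM as the hydroxy-free reference, a modest step toward a lower number is expected, estimated as an at least 6.6-fold lower number from compound 3 to compound 4 (0.82 log units; beyond the scatter) here. The estimate for compound 4 is 15000 nM as the expected value, with 3000 nM to 80000 nM as its range.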

Compound 4, concentration for 50% growth inhibition: 7000 nM
Estimate against measurement, compound 4: 2.1-fold (0.33 log units) above, and the stated range covers the measured number.
By their numbers in this assay, from the lowest: compounds 1 and 4 (each within the scatter of the next); then compound 2. At a limit, above all of these: compound 3.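

Methylsulfanyl in place of hydroxy, on an aromatic carbon para to a large group, gives an at least 14-fold lower number from compound 3 to compound 4 (1.15 log units; beyond the scatter), the first change shown at this position of this ring. Compound 3 has a limit and not a number, so that size is only a floor: the limit of > 100000 nM in this assay, at which 1 of the 4 values shown sits.
The other two steps are a 7.1-fold lower number from compound 2 to compound 4 (0.85 log units; beyond the scatter) and a 1.4-fold higher number from compound 1 to compound 4 (0.15 log units; within the scatter), so the two hydroxy-free compounds cannot be told apart here.

On these data alone, whether the sulfur matters, or only the loss of the hydroxy, stays open. So does the effect of an amine or a carboxylic acid at this position.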